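The compounds below may be only part of what the source reports. "The series", "measured", "known", "first", "only" and "open" are said of these compounds alone.

Measured compounds in a functional assay on HCC827 cells (Homo sapiens) for inhibition, read by fluorescence, with a stated time of 72 h; a higher number here means a weaker inhibitor of growth, a lower number a stronger inhibitor of growth:
compound 1 `CC(C)CCn1cnc2c(NCc3cccc(Cl)c3)nc(N[C@H]3CC[C@H](N)CC3)nc21` gives 16700 nM
compound 2 `CCCCn1cnc2c(Nc3ccc(Cl)cc3)nc(N[C@H]3CC[C@H](N)CC3)nc21` gives 10800 nM
compound 3 `CCCCn1cnc2c(Nc3cccc(Cl)c3)nc(N[C@H]3CC[C@H](N)CC3)nc21` gives 7200 nM

Compound 3 holds the lowest number of the three, with compound 2 within the scatter of it and compound 1 beyond it. Among the compounds with values here, the only single-place step known, a 1.5-fold lower number from compound 2 to compound 3 (0.18 log units; within the scatter), concerns the chlorophenyl and not the group on the aromatic nitrogen. Compound 4 `COc1ccc(Cn2cnc3c(Nc4cccc(Cl)c4)nc(N[C@H]4CC[C@H](N)CC4)nc32)cc1` differs from compound 3 by 4-methoxyphenyl in place of propyl on a saturated chain carbon bound to an aromatic nitrogen. Compound 1 and compound 3 differ in two places, so their values say nothing separate about the chain on the aromatic nitrogen. Within the data shown here, no measured step bears directly on this change, so no step beyond the scatter is expected in this assay. The estimate for compound 4 is 7000 nM, range 2500 nM to 20000 nM, a step of a 1.0-fold lower number from compound 3 to compound 4 (0.01 log units; within the scatter).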

Compound 4, concentration for 50% growth inhibition: 18700 nM
Compound 4: the middle estimate sits 2.7-fold (0.43 log units) below what was measured; the range from low to high includes it.
By their numbers in this assay, from the lowest: compounds 3, 2, 1 and 4 (each within the scatter of the next, the first and the last beyond it).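

In this assay, the chain on the aromatic nitrogen proves able to shift growth inhibition: 4-methoxyphenyl in place of propyl on a saturated chain carbon gives a 2.6-fold higher number from compound 3 to compound 4 (0.41 log units; beyond the scatter), a weaker result. Within the data shown here, this is the first single-place step at this position, and the only one here beyond the scatter. No measurement on hand accounts for it.

From the compounds shown here alone, whether the step belongs to the added aromatic ring or to its methoxy group stays open. An unsubstituted benzyl at this position would separate the two, and a chain ending in a carboxylic acid would test a different kind of group.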